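Thiazole in place of trifluoromethyl-tolyl on the amide carbonyl

The source may hold more compounds than are shown below. What is called first, only, known or untested is meant among the compounds shown, and "the series" means these compounds.

Measured compounds:
Compound 1 `CCCc1ccc(C(=O)Nc2cccc(NC(=O)COc3ccc4c(=O)ccoc4c3)c2)cc1`: 143 nM
Compound 2 `O=C(COc1ccc2c(=O)ccoc2c1)Nc1cccc(NC(=O)c2cccc([N+](=O)[O-])c2)c1`: 528 nM
Compound 3 `Cc1cc(C(=O)Nc2cccc(NC(=O)COc3ccc4c(=O)ccoc4c3)c2)ccc1C(F)(F)F`: 460 nM

In an assay on isolated protein for inhibition of Rho-associated protein kinase 1 (Homo sapiens), read by scintillation counting, radiometric assay and 33P incorporation, with a stated time of 40 min, in the presence of a further agent that is not named here (a higher number here means a weaker inhibitor, a lower number a stronger inhibitor), compound 1 gives 143 nM. Compound 3, with a ring bearing a methyl group and a trifluoromethyl group on the carbonyl carbon, sits beyond the scatter above compound 1, as shown by a 3.2-fold higher number from compound 1 to compound 3 (0.51 log units; beyond the scatter), while its number and that of compound 2 lie within the scatter of each other, as shown by a 1.1-fold lower number from compound 2 to compound 3 (0.06 log units; within the scatter). Compound 4 `Cc1nc(C(=O)Nc2cccc(NC(=O)COc3ccc4c(=O)ccoc4c3)c2)cs1` has not yet been measured; it differs from compound 3 in that (a group of 6 heavy atoms (4 carbon, 1 nitrogen, 1 sulfur; one five-membered aromatic ring with 2 hetero atoms) in place of a group of 11 heavy atoms (8 carbon, 3 fluorine; one six-membered aromatic ring of carbon only), on a carbonyl carbon). For the measured compounds named here, two measured steps bear on this position: a 3.7-fold higher number from compound 1 to compound 2 (0.57 log units; beyond the scatter) and a 3.2-fold higher number from compound 1 to compound 3 (0.51 log units; beyond the scatter), both modest and in the same direction, while the exchange between compound 2 and compound 3 stays within the scatter. Going by the values given here, no measured step introduces a five-membered heteroaromatic ring here, so the direction for compound 4 is uncertain. Compound 4 is therefore expected to remain near compound 3, with a 1.3-fold higher number from compound 3 to compound 4 (0.12 log units; within the scatter) estimated at no more than a modest change. Compound 4 is estimated at 600 nM, in a range from 200 nM to 1800 nM.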

Compound 4, half-maximal inhibitory concentration: 473 nM
Estimate against measurement, compound 4: 1.3-fold (0.10 log units) above; low and high end bracket the measured number.
By their numbers in this assay, from the lowest: compound 1; then compounds 3, 4 and 2 (each within the scatter of the next).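

The 2-methyl-1,3-thiazol-4-yl group, the only five-membered aromatic ring with 2 hetero atoms among these compounds, gives a number indistinguishable from those of both substituted phenyl rings (a 1.0-fold higher number from compound 3 to compound 4 (0.01 log units; within the scatter); a 1.1-fold lower number from compound 2 to compound 4 (0.05 log units; within the scatter)). This position on the carbonyl carbon therefore accepts this ring in place of the group of compound 3 without a change beyond the scatter, and compounds 2, 3 and 4 now form one level despite their different rings. Only compound 1, with its 4-propylphenyl group, stands apart from the thiazole (a 3.3-fold higher number from compound 1 to compound 4 (0.52 log units; beyond the scatter)), and nothing measured here accounts for this.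

Going by these compounds, it remains open whether the propyl chain accounts for that gap. A 2-propyl-1,3-thiazol-4-yl group or an unsubstituted phenyl ring on this carbonyl carbon would help to separate the effect of the chain from that of the ring.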